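Swapping fluoro for methoxy on the outer ring

A few compounds are considered here, and "the series" means these few. Any claim that something is new, unique, unknown or untested is made for them only; others in the source may bear on it.

compound 1, `Oc1ccccc1CNc1ccc(F)cc1`: "not active" (no number reported)
compound 2, `CN1CCN(c2ccc(NCc3ccccc3O)cc2)CC1`: "not active" (no number reported)
compound 3, `Oc1ccccc1CNc1ccc(-c2ccc(F)cc2)cc1`: 3860 nM

Three compounds share a core in which a phenol-bearing benzylamine is joined to a second aromatic ring. In a functional assay on Jurkat cells (Homo sapiens) for activation, with a stated time of 24 h (on this read-out lower numbers stand for an effect already at smaller amounts and higher numbers for an effect only at larger amounts of compound), compound 1 is reported as "not active" (no number reported) and compound 2 as "not active" (no number reported), with no number given for either. Compound 3 is the one entry with a measured number, and in this assay compound 3 gives 3860 nM; it therefore stands alone among the numbers shown, with nothing to compare it against.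

Compound 4, `COc1ccc(-c2ccc(NCc3ccccc3O)cc2)cc1`, is the next variation. It differs from compound 3 by methoxy in place of fluoro on an aromatic carbon. Among the compounds with values here, no step between two measured compounds is available, so the size of this change can only be guessed. A swap of this kind, at this position, is expected to stay within the usual scatter rather than move the value in a clear direction. Compound 4 is accordingly expected to give about 3500 nM in this assay, somewhere between 1200 nM and 10000 nM, which would mean an expected step of a 1.1-fold lower number from compound 3 to compound 4 (0.04 log units; within the scatter).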

Compound 4, half-maximal effective concentration: 580 nM
Compound 4: the middle estimate sits 6.0-fold (0.78 log units) above what was measured, and the stated range ends above it.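

Changing the group at the far end of the outer ring is enough to shift the read-out: with methoxy in place of fluoro, this assay shows a 6.7-fold lower number from compound 3 to compound 4 (0.82 log units; beyond the scatter) for this single swap. Within the data shown here, this is the first measured step, because compound 1 and compound 2 carry no numbers. It shows that this position on the aromatic carbon, para to a large group, does not tolerate every change without effect, and that methoxy gives the lower number of the two groups compared here. Nothing at hand explains why the two groups differ.

The compounds shown leave open whether a longer chain such as ethoxy, a hydroxyl or an amine at this place would lower the number further or raise it. They also leave open whether the same swap would have a similar effect at another position on the outer ring.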